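Dimethoxyphenyl Replaces Methylphenyl on a Flavone Core

The compounds below may be only part of what the source reports. "The series", "measured", "known", "first", "only" and "open" are said of these compounds alone.

Two measured compounds frame this series. Compound 1 `COc1cc(C(=O)/C=C/c2cc(OC)c(OC)c(OC)c2)ccc1O` gives 7560 nM in an ADME assay on MDCK-II cells (Canis lupus familiaris) for inhibition, read by MTT assay, with a stated time of 72 h (a lower number here means a stronger inhibitor of growth, a higher number a weaker inhibitor of growth), and compound 3 `COc1cccc(/C=C/C(=O)c2ccc(OCC(=O)Nc3ccc(OC)c(OC)c3)cc2)c1` gives 33200 nM in the same test. Compound 2 `Cc1ccc(-c2c(OCC(=O)Nc3cccc4ccccc34)oc3ccccc3c2=O)cc1` was tested in this assay but its entry there reads "not determined" (no result reported), so it has no number to stand on here. Compound 4 `COc1ccc(-c2c(OCC(=O)Nc3cccc4ccccc34)oc3ccccc3c2=O)cc1OC` differs from compound 2 in one place: 3,4-dimethoxyphenyl in place of 4-methylphenyl on an aromatic carbon. Among the measured compounds shown here, with no measured step to lean on, the size of this change in this assay cannot be read from the data; it is expected to stay within the usual scatter, in either direction. On the values of compound 1 and compound 3, compound 4 is expected to give about 15000 nM, between 3000 nM and 70000 nM.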

Compound 4, concentration for 50% growth inhibition: > 100000 nM
Compound 4 ended at the assay's limit; the forecaster's own chance of this, stated with the estimate: 25%; middle value at least 6.6-fold (0.82 log units) away from the limit.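

No step can be read between compound 2 and compound 4: compound 2 has no reported result, and compound 4 reaches only a limit of the test. On these data alone, the effect of replacing 4-methylphenyl with 3,4-dimethoxyphenyl on growth inhibition remains open.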